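Series notes: aryl swap on the pyridine-linked anilines

The source may hold more compounds than are shown below. What is called first, only, known or untested is meant among the compounds shown, and "the series" means these compounds.

Two purine-type compounds sharing the same core have been measured so far. Compound 1 `COc1ccccc1-c1ccc(Nc2nc(N[C@H]3CC[C@H](N)CC3)nc3c2ncn3C2CCCC2)cc1` carries a 2-methoxyphenyl group on an aminophenyl ring; in a functional assay on HCC827 cells (Homo sapiens) for inhibition, read by fluorescence and resazurin assay, with a stated time of 72 h (a higher number here means a weaker inhibitor of growth, a lower number a stronger inhibitor of growth), compound 1 gives 2300 nM. Compound 2 `N[C@H]1CC[C@H](Nc2nc(Nc3ccc(-c4cccs4)nc3)c3ncn(C4CCCC4)c3n2)CC1` carries a thiophen-2-yl group on a pyridine ring and gives 652 nM in this assay, the lower of the two numbers, the gap to compound 1 lying beyond the scatter. The two differ in more than one place, so no single step can be read from them.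

Compound 3 `COc1ccc(-c2ccc(Nc3nc(N[C@H]4CC[C@H](N)CC4)nc4c3ncn4C3CCCC3)cn2)cc1` is the next member: 4-methoxyphenyl in place of thiophen-2-yl on an aromatic carbon. The 4-methoxyphenyl group enters on the aromatic carbon next to the ring nitrogen, in place of the thiophen-2-yl group. Among the compounds with values here, no measured pair isolates this exchange. Given that the only other aryl-bearing analogue, compound 1, sits at 2300 nM, a moderate weakening relative to compound 2 is expected, but one that may not clear the scatter. The step from compound 2 to compound 3 in this assay is estimated at a 1.7-fold higher number from compound 2 to compound 3 (0.23 log units; within the scatter). Compound 3 is expected to give 1100 nM in this assay, within the range 350 nM to 3500 nM.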

Compound 3, concentration for 50% growth inhibition: 581 nM
Compound 3: the middle estimate sits 1.9-fold (0.28 log units) above what was measured; the range from low to high includes it.
By their numbers in this assay, from the lowest: compounds 3 and 2 (each within the scatter of the next); then compound 1.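

Within the data shown here, the exchange at this aromatic carbon next to the ring nitrogen is the first single-place change that can be read, and in this assay it comes out as a 1.1-fold lower number from compound 2 to compound 3 (0.05 log units; within the scatter) for replacing thiophen-2-yl with 4-methoxyphenyl. This position therefore accepts a six-movement of ring type, from a five-membered aromatic ring with 1 hetero atom to a six-membered aromatic ring of carbon only, and a group with more heavy atoms, without a change in the growth-inhibition read-out that clears the scatter. Nothing available accounts for why these two aryl groups read alike here.

Among these compounds, compound 1 differs from each of the other two compounds in more than one place, and no step to it can be read. On these data alone, whether this position stays as insensitive for groups of another kind remains open, for instance a primary amine or a morpholine directly on this carbon, or a carboxylic acid or a longer alkoxy chain in place of the methoxy on the phenyl ring.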